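The source may report more compounds than this note shows. Statements on the series, on what has been measured and on what is new or still open speak of the compounds shown alone.

Working notes on the series. In a functional assay on trachea (Cavia porcellus) (a lower number here means a stronger inhibitor, a higher number a weaker inhibitor), compound 1 `CO[C@@]12CCN(C)C[C@H]1[C@H](c1ccc(F)cc1)C(C#N)=C(N)O2` gives 19400 nM, compound 2 `CCCN1CC[C@@]2(OC)OC(N)=C(C#N)[C@@H](c3ccc(F)cc3)[C@@H]2C1` gives 29600 nM, and compound 3 `CO[C@@]12CCN(Cc3ccccc3)C[C@H]1[C@H](c1ccc(F)cc1)C(C#N)=C(N)O2` gives 17200 nM. Compound 2 carries the highest of the three numbers, yet the step of a 1.5-fold higher number from compound 1 to compound 2 (0.18 log units; within the scatter) and the step of a 1.7-fold lower number from compound 2 to compound 3 (0.24 log units; within the scatter) both lie within the scatter, as does a 1.1-fold lower number from compound 1 to compound 3 (0.05 log units; within the scatter), so the three stand level in this assay. Compound 4 `CCCN1CC[C@@]2(OC)OC(N)=C(C#N)[C@@H](c3ccc(OC)cc3)[C@@H]2C1` differs from compound 2 in one place: methoxy in place of fluoro on an aromatic carbon. Within the data shown here, all three measured steps alter the group on the amine nitrogen in the ring; none alters the aromatic ring, so no measured step bears on this change. The expectation for compound 4 is therefore a step of a 1.0-fold higher number from compound 2 to compound 4 (0.01 log units; within the scatter) that stays within the scatter. Compound 4 is estimated at 30000 nM, with a range from 8000 nM to 110000 nM.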

Compound 4, half-maximal inhibitory concentration: 21300 nM
For compound 4 the middle estimate is 1.4-fold (0.15 log units) above the measured one, within the range that was stated.
By their numbers in this assay, from the lowest: compounds 3, 1, 4 and 2 (each within the scatter of the next).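

In this assay, among these compounds, the change from 4-fluorophenyl to 4-methoxyphenyl is the only step that alters the aromatic ring, and it gives a 1.4-fold lower number from compound 2 to compound 4 (0.14 log units; within the scatter). On this single pair, the position para to a large group accepts methoxy in place of fluoro without a change beyond the scatter. No measurement at hand offers an explanation for this result. Open, as far as these compounds go, is whether an amine, a carboxylic acid or a longer chain at this position would also stay level with compound 2. Also open, from the compounds shown here alone, is whether the methoxy for fluoro change reads the same with another group on the amine nitrogen in the ring.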